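Amine swap on the thiocarbonyl carbon: compound 3 to 4

The source may report more compounds than this note shows. Statements on the series, on what has been measured and on what is new or still open speak of the compounds shown alone.

Three compounds share one core and differ only in the amine on the thiocarbonyl carbon. Compound 1 `CN(C(=S)SCc1ccc(C(=O)Nc2ccccc2N)cc1)c1cccnc1` gives 26.5% in a functional assay on A-375 cells (Homo sapiens) for antiproliferative activity, read by CCK-8 assay, with a stated time of 72 h, tested at 2 uM; a higher number here means a stronger effect of the compound at the concentration tested, a lower number a weaker effect. Compound 2 `CC1CCCCN1C(=S)SCc1ccc(C(=O)Nc2ccccc2N)cc1` gives 42.5%, and compound 3 `CC1CCN(C(=S)SCc2ccc(C(=O)Nc3ccccc3N)cc2)CC1` gives 32.7%. Compound 3 stands second highest of the three numbers, its nearest neighbour being compound 1 and its furthest compound 2, both within the scatter. For the measured compounds named here, the single step beyond the scatter is a number 16 percentage points higher from compound 1 to compound 2 (beyond the scatter); the steps of a number 6.2 percentage points higher from compound 1 to compound 3 (within the scatter) and a number 9.8 percentage points lower from compound 2 to compound 3 (within the scatter) stay within it.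

Compound 4 `CN1CCN(C(=S)SCc2ccc(C(=O)Nc3ccccc3N)cc2)CC1` carries the change (4-methylpiperazin-1-yl in place of 4-methylpiperidin-1-yl on a thiocarbonyl carbon). Going by the values given here, no measured step exchanges a ring carbon for a ring nitrogen; the only comparison between two saturated rings, a number 9.8 percentage points lower from compound 2 to compound 3 (within the scatter), shows that swapping 2-methylpiperidin-1-yl for 4-methylpiperidin-1-yl leaves the number within the scatter. On that basis the step of a number 2.7 percentage points lower from compound 3 to compound 4 (within the scatter) is expected to be small, with no direction claimed beyond the scatter. Compound 4 is therefore estimated at 30%, with a range from 15% to 48%.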

Compound 4, a percentage reported as inhibition, at one concentration (the size of the read-out at that concentration, not a potency): 36.6%
Compound 4: middle estimate off by 6.6 percentage points, on the low side, and the stated range covers the measured number.
By their numbers in this assay, from the lowest: compounds 1, 3, 4 and 2 (each within the scatter of the next, the first and the last beyond it).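

Exchanging a ring carbon for a ring nitrogen, with 4-methylpiperazin-1-yl in place of 4-methylpiperidin-1-yl on a thiocarbonyl carbon, gives a number 3.9 percentage points higher from compound 3 to compound 4 (within the scatter) in this assay, so the hydrogen-bond acceptor that enters with this ring produces no readable change here. The other saturated ring gives a number 5.9 percentage points lower from compound 2 to compound 4 (within the scatter), which places all three saturated-ring amines within the scatter of one another, while the step from the pyridinyl amine is a number 10.1 percentage points higher from compound 1 to compound 4 (beyond the scatter), a separation that compound 3 does not share with compound 1. No available evidence bears on the cause of these steps.

On these data alone, it remains open whether a morpholin-4-yl ring, or a piperazine ring with a longer chain in place of the methyl, would stay within this band. A single tested concentration also leaves the potency of these compounds open.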